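This account rests on a few compounds, and the source may have more. Where it says the series, first, only, none or still open, it means among the compounds named here.

Working notes on a small set sharing one core, all run in a functional assay on MDA-MB-231 cells (Homo sapiens) for inhibition, read by MTT assay, with a stated time of 48 h; a higher number here means a weaker inhibitor, a lower number a stronger inhibitor. Compound 3 `COc1ccc2[nH]cc(C3CC(c4ccncc4)=NO3)c2c1` returns only a limit in this assay, > 100000 nM, which is the limit of > 100000 nM in this assay, at which 1 of the 3 values shown sits. Compound 1 `COc1ccc2c(c1)c(C1CC(c3ccncc3)=NO1)cn2Cc1ccc(Cl)cc1` carries the change 4-chlorobenzyl in place of hydrogen on an aromatic nitrogen on the core of compound 3; in this assay compound 1 gives 26000 nM, so the step is an at least 3.8-fold lower number from compound 3 to compound 1 (0.58 log units; beyond the scatter). Compound 2 `COc1ccc2c(C3CC(c4ccncc4)=NO3)c[nH]c2c1` has the same atoms as compound 3 joined differently; the difference between the two cores is not broken down here. In this assay compound 2 gives 7380 nM, the lowest of the two numbers in hand.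

Compound 4 `COc1ccc2c(C3CC(c4ccncc4)=NO3)cn(Cc3ccc(Cl)cc3)c2c1` has not yet been measured; it bears on the core of compound 2 the change (4-chlorobenzyl in place of hydrogen on an aromatic nitrogen). The place of the change reads the same as for compound 1, so this is the same change. From the compounds shown here alone, the step from compound 2 to compound 4 is expected to be a 3.0-fold lower number from compound 2 to compound 4 (0.47 log units; beyond the scatter), resting on the earlier step, whose true size is unknown since compound 3 sits at a limit. Compound 4 is therefore estimated at 2500 nM in this assay, between 700 nM and 9000 nM.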

Compound 4, half-maximal inhibitory concentration: > 100000 nM
Compound 4: a limit, no number; the forecaster's own chance of this, stated with the estimate: 3%; middle value at least 40-fold (1.60 log units) away from the limit.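

In this assay, 4-chlorobenzyl in place of hydrogen on an aromatic nitrogen gives an at least 13-fold higher number from compound 2 to compound 4 (1.13 log units; beyond the scatter), so the change does not carry from one core to the other and its direction reverses: the same change on two cores in this assay, an at least 3.8-fold lower number (0.58 log units; beyond the scatter) from compound 3 to compound 1 and an at least 13-fold higher number (1.13 log units; beyond the scatter) from compound 2 to compound 4, at least 52-fold (1.71 log units) apart, beyond the scatter of two such steps. Neither step has a known true size, and the gap between them is known only as a minimum, as each step has a limit at one end, not a number: the limit of > 100000 nM in this assay, at which 2 of the 4 values shown sit. The two pairs show that the outcome of this change depends on the core among these four compounds, but they do not show which difference between the cores is responsible or how the change would behave on any further core.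

The compounds shown leave open whether a methyl, a plain benzyl or a chain ending in an amine on that aromatic nitrogen would separate the two cores in the same way. From the compounds shown here alone, it also remains open whether the reversal would appear with a carboxylic acid on the benzyl ring in place of the chlorine.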